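Removing a Fluorine from a NOTUM Inhibitor

The source may hold more compounds than are shown below. What is called first, only, known or untested is meant among the compounds shown, and "the series" means these compounds.

Of the compounds shown here, three have been measured in an assay on cells for inhibition of Palmitoleoyl-protein carboxylesterase NOTUM variant C330S (Homo sapiens), read by fluorescence, with a stated time of 40 min; a higher number here means a weaker inhibitor, a lower number a stronger inhibitor. Compound 1 `O=C(O)C1CCN(c2ccccc2Cl)C1` gives 19000 nM. Compound 2 `Cc1cc(C(=O)O)c(C)n1-c1cccc(C#N)c1F`, which carries both a cyano group and a fluoro on its six-membered aromatic ring, gives 630 nM, the lowest of the three numbers. Compound 3 `Cc1cc(C(=O)O)c(C)n1-c1ccccc1F` gives 3300 nM. For the measured compounds named here, the only single change measured so far is a 5.2-fold higher number from compound 2 to compound 3 (0.72 log units; beyond the scatter), so taking away the cyano group costs a modest amount of inhibition.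

Compound 4 `Cc1cc(C(=O)O)c(C)n1-c1cccc(C#N)c1` has not yet been measured. It differs from compound 2 in one place: hydrogen in place of fluoro on an aromatic carbon. Going by the values given here, no measured step removes a fluoro, and the step from compound 2 to compound 3 speaks only to the cyano group, which compound 4 keeps. With no direct guide, a change no larger than the usual scatter is expected, perhaps a slight rise in the number. Compound 4 is therefore estimated at 900 nM, with a range from 350 nM to 2500 nM. That estimate means an expected step of a 1.4-fold higher number from compound 2 to compound 4 (0.15 log units; within the scatter).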

Compound 4, half-maximal inhibitory concentration: 3100 nM
Estimate against measurement, compound 4: 3.4-fold (0.54 log units) below, and the stated range ends below it.
By their numbers in this assay, from the lowest: compound 2; then compounds 4 and 3 (each within the scatter of the next); then compound 1.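

Replacing the fluoro with hydrogen on this aromatic carbon, ortho to a cyano group, gives a 4.9-fold higher number from compound 2 to compound 4 (0.69 log units; beyond the scatter) in this assay, so even this one-atom change lowers inhibition by more than the usual variation between repeats. Removing the cyano group gives a 5.2-fold higher number from compound 2 to compound 3 (0.72 log units; beyond the scatter), so the removal of either group from compound 2 now has a measured cost, and in both cases the step lies beyond the scatter. Nothing available explains why the fluoro matters at this position.

On these data alone, it remains open whether a methoxy group or a bromine atom at this position would match the fluoro, or give a lower or higher number. Also open, as far as these compounds go, is what hydrogen in place of both the fluoro and the cyano group would give.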